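The compounds below may be only part of what the source reports. "The series", "measured", "known", "first", "only" and "open" are said of these compounds alone.

Measured in a functional assay on NCI-H460 cells (Homo sapiens) for antiproliferative activity, read by MTT assay, with a stated time of 48 h; a higher number here means a weaker inhibitor, a lower number a stronger inhibitor:
- compound 1 `COc1cc(-c2cccc3nc(-c4ccccc4)oc23)cc(OC)c1OC`: 6800 nM
- compound 2 `COc1cc(-c2cccc3nc(-c4cccc(F)c4)oc23)cc(OC)c1OC`: 3300 nM

Of these two compounds, compound 2 has the lower number, 3300 nM, which makes it the stronger inhibitor in this assay. The next compound, compound 3 `COc1cc(-c2cccc3nc(-c4cccc(Cl)c4)oc23)cc(OC)c1OC`, differs from it at a single place: chloro in place of fluoro on an aromatic carbon. This puts chloro in place of fluoro on an aromatic carbon, meta to a large group, turning 3-fluorophenyl into 3-chlorophenyl.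

Among the measured compounds shown here, only one measured step bears on this change: a 2.1-fold lower number from compound 1 to compound 2 (0.31 log units; beyond the scatter). That step was modest and put fluoro in place of hydrogen on an aromatic carbon. For the measured compounds named here, no measured pair compares fluoro with chloro directly, so the evidence is thin. Going by the values given here, since the one step at this place was only a 2.1-fold lower number from compound 1 to compound 2 (0.31 log units; beyond the scatter), a step no larger than that is expected, and probably none beyond the scatter, with no firm direction. The expected change is a 1.1-fold lower number from compound 2 to compound 3 (0.04 log units; within the scatter). For compound 3 the estimate is 3000 nM, with an expected range of 1300 nM to 7000 nM.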

Compound 3, half-maximal inhibitory concentration: > 25000 nM
Compound 3 gave a limit, no number; the forecaster's own chance of this, stated with the estimate: 2%; middle value at least 8.3-fold (0.92 log units) from the limit.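

In this assay compound 3 gives a limit and not a number, the only such result among the compounds shown: the limit of > 25000 nM in this assay, at which 1 of the 3 values shown sits.

Exchanging fluoro for chloro at this place gives an at least 7.5-fold higher number from compound 2 to compound 3 (0.87 log units; beyond the scatter), a far larger shift than the earlier compounds had shown at this position. Chloro in place of hydrogen gives an at least 3.6-fold higher number from compound 1 to compound 3 (0.56 log units; beyond the scatter), which runs opposite to the modest fluoro step, a 2.1-fold lower number from compound 1 to compound 2 (0.31 log units; beyond the scatter), so at this position the read-out depends on which halogen is present and not merely on whether one is there.

From the compounds shown here alone, as the steps to compound 3 rest on a limit, they fix only a minimum, and the full size of the loss stays unknown. The compounds shown also leave open how bromo, methyl, methoxy or an amine would behave at this place, and whether chloro would have the same effect elsewhere on this ring.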